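This account rests on a few compounds, and the source may have more. Where it says the series, first, only, none or still open, it means among the compounds named here.

Measured compounds and their values:
Compound 1 `C/C=C1/[C@H](O[C@@H]2O[C@H](COC(C)=O)[C@@H](OC(C)=O)[C@H](OC(C)=O)[C@H]2OC(C)=O)OC=C(C(=O)OC)[C@H]1CC(=O)OCCC` gives 6600 nM in a functional assay on SK-BR-3 cells (Homo sapiens) for antiproliferative activity, read by MTT assay, with a stated time of 72 h; on this read-out higher numbers stand for weaker inhibition and lower numbers for stronger inhibition.
Compound 2 `C/C=C1/[C@H](O[C@@H]2O[C@H](CO)[C@@H](O)[C@H](O)[C@H]2O)OC=C(C(=O)OC)[C@H]1CC(=O)OCCc1ccc(F)cc1` gives > 20000 nM in this assay, which is a limit of the assay, not a number.
Compound 3 `C/C=C1/[C@H](O[C@@H]2O[C@H](CO)[C@@H](O)[C@H](O)[C@H]2O)OC=C(C(=O)OC)[C@H]1CC(=O)OCCCC` gives > 15000 nM in this assay, again a limit of the assay rather than a number.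

Among the measured compounds shown here, compound 1 therefore stands as the only compound of the three with a measured number in this assay; the other two values sit at limits, namely the limit of > 15000 nM in this assay, at which 1 of the 3 values shown sits, and (the limit of > 20000 nM in this assay, at which 1 of the 3 values shown sits). For the measured compounds named here, the one step between measured compounds, a step that the two limits leave unreadable from compound 2 to compound 3, is left unreadable by those two limits, and it concerns a different place in the molecule, a saturated chain carbon, in compounds whose sugar carries free hydroxyls rather than the acetylated sugar of compound 1.

Compound 4 `C/C=C1/[C@H](O[C@@H]2O[C@H](COC(C)=O)[C@@H](OC(C)=O)[C@H](OC(C)=O)[C@H]2OC(C)=O)OC=C(C(=O)OC)[C@H]1CC(=O)SCCc1ccccc1` differs from compound 1 by phenethylsulfanyl in place of propoxy on a carbonyl carbon. Going by the values given here, no measured step touches this carbonyl carbon or either of these groups, so there is no evidence in hand to call a direction for the change. The expectation for compound 4 is accordingly a value close to that of compound 1, with wide uncertainty: an estimated 6000 nM in this assay, between 1500 nM and 20000 nM, which amounts to an expected step of a 1.1-fold lower number from compound 1 to compound 4 (0.04 log units; within the scatter).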

Compound 4, half-maximal inhibitory concentration: > 15000 nM
Compound 4 gave a limit, no number (the forecaster's own chance of this, stated with the estimate: 25%); middle value at least 2.5-fold (0.39 log units) from the limit.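

Among the compounds shown here, the exchange of propoxy for phenethylsulfanyl on a carbonyl carbon gives the first readable step at this position in this assay, an at least 2.2-fold higher number from compound 1 to compound 4 (0.35 log units; beyond the scatter), so with the acetylated sugar kept, this change does not preserve the activity of compound 1. The change alters two things at once, as sulfur takes the place of oxygen on the carbonyl carbon and a six-membered aromatic ring enters, and the step cannot be assigned to either one alone. The step gives only a minimum size, and its full size cannot be read, because compound 4 sits at a limit of the assay rather than at a number: the limit of > 15000 nM in this assay, at which 2 of the 4 values shown sit.

What the compounds shown leave open is which of the two alterations carries the loss, a question that a phenethoxy group or a propylsulfanyl group on the same carbonyl carbon would separate. They also leave open how an amide formed from a simple amine would read at this position, and whether the exchange would give a readable step in compounds whose sugar carries free hydroxyls.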